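Sulfanyl to Hydroxy on a Shared Core

A few compounds are considered here, and "the series" means these few. Any claim that something is new, unique, unknown or untested is made for them only; others in the source may bear on it.

Of the compounds shown here, three built on one shared core have been tested in a functional assay for inhibition, with Homo sapiens as the target; a lower number here means a stronger inhibitor, a higher number a weaker inhibitor. Compound 1 `Cc1nc(C(C)C)n2c(O)nnc(-c3ccccc3)c12` carries a hydroxy group; in this assay compound 1 gives > 48000 nM, which is a limit of the assay rather than a number. Compound 2 `CSc1nncc2c(C)nc(C(C)C)n12` carries a methyl on a sulfur; in this assay compound 2 gives > 48000 nM, again only a limit. Compound 3 `Cc1nc(C(C)C)n2c(S)nncc12` carries a sulfanyl group; in this assay compound 3 gives > 48000 nM, also a limit. For the measured compounds named here, the single step between measured compounds, a step that the two limits leave unreadable from compound 2 to compound 3, cannot be read because of the limit of > 48000 nM in this assay, at which 3 of the 3 values shown sit. Compound 3 therefore stands at the limit, with nothing to rank it against the other two.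

Compound 4 `Cc1nc(C(C)C)n2c(O)nncc12` differs from compound 3 in one place: hydroxy in place of sulfanyl on an aromatic carbon. Going by the values given here, no measured step bears on this change, and compound 1, which also carries a hydroxy group, gives only a limit. Compound 4 is therefore expected to give 60000 nM, within 20000 nM to 200000 nM, most probably as a limit once more, so that the expected step that the limit leaves unreadable from compound 3 to compound 4 would not be readable beyond the scatter.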

Compound 4, half-maximal inhibitory concentration: > 48000 nM
Compound 4: only a limit was reported; the forecaster's own chance of this, stated with the estimate: 85%; the middle value is on the limit's open side.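

Compound 4 gives > 48000 nM in this assay, again a limit and not a number. The steps to compound 4 from compound 1, compound 2 and compound 3 therefore cannot be read: the limit of > 48000 nM in this assay, at which 4 of the 4 values shown sit.

The compounds shown leave open how hydroxy and sulfanyl truly compare, and whether any compound on this shared core reaches a measurable inhibition.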